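The source may hold more compounds than are shown below. What is called first, only, known or untested is meant among the compounds shown, and "the series" means these compounds.

Measured in a functional assay on U377-MG cells (Homo sapiens) for inhibition, read by thymidine incorporation, with a stated time of 36 h; on this read-out lower numbers stand for stronger inhibition and higher numbers for weaker inhibition:
Compound 1 `CCCCCCCCCCCCCCCCO[C@H]1O[C@H](CO)[C@@H](O)[C@H](O)[C@H]1NC(C)=O`: 13 uM
Compound 2 `CCCCCCCCCCCCCCCCO[C@H]1O[C@H](COCC(CO)(CO)COS(=O)(=O)O)[C@@H](O)[C@H](O)[C@H]1NC(=O)CCCC`: 3.2 uM

Of these two, compound 2 has the lower number at 3.2 uM, and its gap to compound 1 lies beyond the usual scatter. Compound 3 `CCCCCCCCCCCCCCCCO[C@H]1O[C@H](COCC(O)CO)[C@@H](O)[C@H](O)[C@H]1NC(=O)CCCC` keeps the shared core of compound 2 but has 1,2-dihydroxyethyl in place of 2-hydroxy-1-(hydroxymethyl)-1-((sulfooxy)methyl)ethyl, on a saturated chain carbon bound to an oxygen on a saturated carbon (1,2-dihydroxyethyl in place of 2-hydroxy-1-(hydroxymethyl)-1-((sulfooxy)methyl)ethyl on a saturated chain carbon bound to an oxygen on a saturated carbon). Among the measured compounds shown here, no measured pair differs in one place only, so this change has no direct precedent. For the measured compounds named here, the sole guide is compound 1 at 13 uM, which differs from compound 2 in more than one place. A modest rise in this assay, towards weaker inhibition, is therefore expected. The estimated change is a 2.2-fold higher number from compound 2 to compound 3 (0.34 log units; beyond the scatter). Compound 3 is estimated at 7 uM, with an expected range of 2.5 uM to 20 uM.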

Compound 3, concentration for 50% inhibition: 4.6 uM
For compound 3 the middle estimate is 1.5-fold (0.18 log units) above the measured one; the range from low to high includes it.
By their numbers in this assay, from the lowest: compounds 2 and 3 (each within the scatter of the next); then compound 1.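

In this assay, replacing 2-hydroxy-1-(hydroxymethyl)-1-((sulfooxy)methyl)ethyl with 1,2-dihydroxyethyl on a saturated chain carbon bound to an oxygen on a saturated carbon gives a 1.4-fold higher number from compound 2 to compound 3 (0.16 log units; within the scatter). Among the compounds shown here, this is the first direct reading of this position, and it shows that the group can go from 11 heavy atoms to 4 heavy atoms, losing the sulfur and the sulfooxy part, without a difference beyond the scatter in this read-out. Nothing available explains this outcome. The compounds shown leave open whether a carboxylic acid or an amine in this place, or a longer chain carrying the sulfooxy group, would read differently. Also open, on these data alone, is what the acyl chain on the amide contributes on its own, as compound 1 differs from the others in more than one place.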